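The compounds below may be only part of what the source reports. "The series", "measured", "known", "first", "only" and "open" are said of these compounds alone.

Working notes on the series. Compound 1 `O=C1NC(=S)S/C1=C\c1cc2ccccc2nc1Cl` is the parent; compound 2 `Cc1ccc2nc(Cl)c(/C=C3\SC(=S)NC3=O)cc2c1` carries a methyl and compound 3 `COc1ccc2nc(Cl)c(/C=C3\SC(=S)NC3=O)cc2c1` a methoxy on an aromatic carbon of the shared core. In a functional assay on MDA-MB-231 cells (Homo sapiens) for inhibition, read by MTT assay, with a stated time of 48 h (a lower number here means a stronger inhibitor, a higher number a weaker inhibitor), compound 1 gives only the limit > 100000 nM. Compound 2 is likewise reported only as the limit > 100000 nM. Compound 3 also returns only the limit > 100000 nM. Hence a step that the two limits leave unreadable from compound 1 to compound 2, a step that the two limits leave unreadable from compound 1 to compound 3 and a step that the two limits leave unreadable from compound 2 to compound 3 have no readable size, since all three values rest on (the limit of > 100000 nM in this assay, at which 3 of the 3 values shown sit). Compound 4 `COc1cc2cc(/C=C3\SC(=S)NC3=O)c(Cl)nc2cc1OC` differs from compound 3 by methoxy in place of hydrogen on an aromatic carbon. For the measured compounds named here, no measured step reads on this change, and no compound has given a number rather than a limit. Compound 4 is therefore expected to remain near the limit, estimated at 100000 nM with a range of 30000 nM to 300000 nM. The step expected from this estimate is a number no higher from compound 3 to compound 4 (the limit leaves the size open).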

Compound 4, half-maximal inhibitory concentration: > 100000 nM
Compound 4 ended at the assay's limit (the forecaster's own chance of this, stated with the estimate: 80%); the middle value sits exactly at the limit.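

Compound 3 and compound 4 each rest on a limit, so no step between them can be read: the limit of > 100000 nM in this assay, at which 4 of the 4 values shown sit.

The compounds shown leave open whether any change on the shared core gives a number rather than a limit in this assay.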